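The compounds below may be only part of what the source reports. "The series", "measured", "known", "first", "only" and "open" are said of these compounds alone.

Compound 1 `Cn1c(-c2ccc(NC(=O)CCl)cc2)nc(-c2ccccc2)c1-c1ccccc1` is the starting point of this comparison. Among the measured compounds shown here, in a functional assay on MCF7 cells (Homo sapiens) for cytotoxicity, read by MTT assay, with a stated time of 24 h, tested at 6.4 ug/mL (on this read-out higher numbers stand for a stronger effect at the one concentration tested and lower numbers for a weaker effect), compound 1 gives 14.2%, the lowest of the three numbers measured so far. Compound 2 `Cn1nnnc1SCC(=O)Nc1ccc(-c2nc(-c3ccccc3)c(-c3ccccc3)n2C)cc1` gives 55.9%, and compound 3 `Cc1nnc(SCC(=O)Nc2ccc(-c3nc(-c4ccccc4)c(-c4ccccc4)n3C)cc2)s1` gives 67.8%. Both differ from compound 1 at the same place, the saturated chain carbon bound to a carbonyl carbon, where the chlorine atom is exchanged for a ring joined through sulfur; the result was a number 41.7 percentage points higher from compound 1 to compound 2 (beyond the scatter) and a number 53.6 percentage points higher from compound 1 to compound 3 (beyond the scatter). Between the two rings themselves the gap was smaller, a number 11.9 percentage points higher from compound 2 to compound 3 (beyond the scatter). Compound 4 `Cn1c(-c2ccc(NC(=O)CSC3=NCCS3)cc2)nc(-c2ccccc2)c1-c1ccccc1` follows the same idea with a different ring: a group of 6 heavy atoms (3 carbon, 1 nitrogen, 2 sulfur; one five-membered non-aromatic ring with 2 hetero atoms) in place of one chlorine atom, on a saturated chain carbon bound to a carbonyl carbon. Since both earlier replacements of the chlorine gave large rises, a large rise is expected here too, though the ring now entering is non-aromatic, so the estimate is kept a little under the measured pair. Compound 4 is therefore expected to give 50%, between 25% and 72%. That would mean an expected step of a number 35.8 percentage points higher from compound 1 to compound 4 (beyond the scatter).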

Compound 4, a percentage reported as activity, at one concentration (the size of the read-out at that concentration, not a potency): 18.6%
Compound 4: the middle estimate sits 31.4 percentage points above what was measured; measured number outside the range, below it.
By their numbers in this assay, from the lowest: compounds 1 and 4 (each within the scatter of the next); then compound 2; then compound 3.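

The sulfur link alone does not lift the read-out at this saturated chain carbon bound to a carbonyl carbon: in this assay, replacing the chlorine with this new group gives a number 4.4 percentage points higher from compound 1 to compound 4 (within the scatter). What is joined to the sulfur therefore matters, as the five-membered non-aromatic ring with 2 hetero atoms gives a number 49.2 percentage points lower from compound 3 to compound 4 (beyond the scatter) and a number 37.3 percentage points lower from compound 2 to compound 4 (beyond the scatter). Among these three rings, the two aromatic ones go with the higher numbers, but nothing available explains the drop.

From the compounds shown here alone, whether aromaticity itself is what counts remains open, since these rings also differ in their hetero atoms. Going by these compounds, it is also open how a simple amine or a carboxylic acid would read in place of the chlorine at this position.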